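The compounds below may be only part of what the source reports. "The series", "measured", "known", "first", "only" and "open" are said of these compounds alone.

Compound 1 `CN(C)CCn1cnnc1-c1cc(Oc2ccc(NC(=O)N/N=C/c3c[nH]c4ccccc34)cc2F)ccn1` is the reference point. Among the compounds with values here, in a functional assay on MKN-45 cells (Homo sapiens) for cytotoxicity, read by MTT assay, with a stated time of 72 h (a higher number here means a weaker inhibitor, a lower number a stronger inhibitor), compound 1 gives 790 nM, the lowest of the three numbers measured so far. Two relatives differ from it only in the group on a carbon with a double bond to nitrogen. Compound 2 `COc1ccc(/C=N/NC(=O)Nc2ccc(Oc3ccnc(-c4nncn4CCN(C)C)c3)c(F)c2)cc1O` carries 3-hydroxy-4-methoxyphenyl there and in this assay gives 2510 nM, a change of a 3.2-fold higher number from compound 1 to compound 2 (0.50 log units; beyond the scatter). Compound 3 `CN(C)CCn1cnnc1-c1cc(Oc2ccc(NC(=O)N/N=C/c3ccc(O)cc3O)cc2F)ccn1` carries 2,4-dihydroxyphenyl and gives 2860 nM, a change of a 3.6-fold higher number from compound 1 to compound 3 (0.56 log units; beyond the scatter). Between those two phenyl variants the step is a 1.1-fold higher number from compound 2 to compound 3 (0.06 log units; within the scatter), so the two hydroxylated phenyl groups behave alike. Compound 4 `CN(C)CCn1cnnc1-c1cc(Oc2ccc(NC(=O)N/N=C/c3cccc(O)c3)cc2F)ccn1` has not yet been measured; it differs from compound 1 in that (3-hydroxyphenyl in place of 1H-indol-3-yl on a carbon with a double bond to nitrogen). Both measured steps that swap 1H-indol-3-yl for a hydroxylated phenyl bear on this change, and both were modest losses of similar size, so a loss of about the same size is expected here, estimated as a 3.2-fold higher number from compound 1 to compound 4 (0.50 log units; beyond the scatter). For compound 4 the expected value in this assay is 2500 nM, with a range from 1200 nM to 5500 nM.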

Compound 4, half-maximal inhibitory concentration: 1370 nM
Compound 4: the middle estimate sits 1.8-fold (0.26 log units) above what was measured, within the range that was stated.
By their numbers in this assay, from the lowest: compounds 1, 4, 2 and 3 (each within the scatter of the next, the first and the last beyond it).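

In this assay, 3-hydroxyphenyl in place of 1H-indol-3-yl gives a 1.7-fold higher number from compound 1 to compound 4 (0.24 log units; within the scatter), so at this carbon a phenyl group can stay within the scatter of 1H-indol-3-yl, which the two earlier hydroxylated phenyl groups of compound 2 and compound 3 did not. The groups on the phenyl ring now also show some effect: 3-hydroxyphenyl in place of 2,4-dihydroxyphenyl gives a 2.1-fold lower number from compound 3 to compound 4 (0.32 log units; beyond the scatter), beyond the scatter, whereas hydrogen in place of methoxy gives a 1.8-fold lower number from compound 2 to compound 4 (0.26 log units; within the scatter), within it. Nothing available here explains these differences.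

On these data alone, it remains open how a phenyl ring with no hydroxyl at all, or one carrying an amine or a carboxylic acid, would compare at this carbon. As far as these compounds go, whether these small steps hold in other cell lines also remains open.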